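This account rests on a few compounds, and the source may have more. Where it says the series, first, only, none or still open, it means among the compounds named here.

Compound 1 `COc1ccc(Cc2nnc(NC(=O)/C(C#N)=C/c3ccccc3OS(=O)(=O)c3ccc(Cl)cc3)s2)cc1`: 20%
Compound 2 `Cc1ccc(S(=O)(=O)Oc2ccccc2/C=C(\C#N)C(=O)Nc2nnc(Cc3cccc4ccccc34)s2)cc1`: 19%
Compound 3 `Cc1ccc(S(=O)(=O)Oc2ccccc2/C=C(\C#N)C(=O)Nc2nnc(Cc3ccc(F)cc3)s2)cc1`: "not active" (no number reported)

These three compounds were examined in a functional assay on HL-60 cells (Homo sapiens) for inhibition, read by CCK-8 assay, with a stated time of 48 h, tested at 20 uM; a lower number here means less inhibition of growth, a higher number more inhibition of growth at the concentration tested. There, compound 1 gives 20% and compound 2 gives 19%, two values within the usual scatter of each other. Compound 3 has no single number to set beside them: it is recorded as "not active" (no number reported), so its place can be told only in those words.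

The account now turns to compound 4 `N#C/C(=C\c1ccccc1OS(=O)(=O)c1ccc(Cl)cc1)C(=O)Nc1nnc(Cc2ccc(F)cc2)s1`, which has not yet been measured in this assay. The structural change is chloro in place of methyl on an aromatic carbon. Put simply, 4-methylphenyl becomes 4-chlorophenyl while the rest of the structure stays as it is.

For the measured compounds named here, no measured pair of compounds shows this change on its own, so the data give no direct size for such a step. With compound 3 recorded as "not active" (no number reported), the expectation is for a modest reading at most, with no rise beyond the scatter of the numbers seen so far. For compound 4 the estimated growth inhibition is 15%, with an expected range from 0% to 40%.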

Compound 4, percent growth inhibition at one concentration: 20%
Compound 4: middle estimate off by 5 percentage points, on the low side, and the stated range covers the measured number.
By their numbers in this assay, from the lowest: compounds 2, 1 and 4 (each within the scatter of the next).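

In this assay compound 4 gives 20%, so a chloro on this aromatic carbon, para to a large group, comes with a measured number, whereas compound 3, with methyl at that carbon, is recorded only in words. The step between compound 3 and compound 4 therefore cannot be read, and the methyl to chloro change still has no size. For the compounds shown here, the pair that can be read keeps the 4-chlorophenyl group on both sides: with fluoro in place of methoxy on the other aromatic ring, the reading shows no change at the digits printed from compound 1 to compound 4 (within the scatter), the first step in this set with a size, and that change leaves the number where it was.

The compounds shown leave open whether an amine, a carboxylic acid or a longer chain in place of chloro on this carbon would carry the growth inhibition any further than the readings seen so far. No measurement of any property is at hand to explain these readings.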